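Cytotoxicity notes: adding a second chloro to compound 1

A few compounds are considered here, and "the series" means these few. Any claim that something is new, unique, unknown or untested is made for them only; others in the source may bear on it.

Compound 1 `O=C(CCSc1nnc(-c2ccncc2)s1)Nc1ccc(Cl)cc1` is the reference point of this small set. In an ADME assay on HepG2 cells (Homo sapiens) for cytotoxicity, with a stated time of 3 days (a lower number here means that less compound is tolerated, a higher number that more compound is tolerated), compound 1 gives 7260 nM, which is the only plain number among the three results shown. Compound 2 `CC(Sc1nnc(-c2ccncc2)s1)C(=O)NCc1ccc(Cl)cc1` carries no result in this assay, recorded as "not determined" (no result reported). Compound 3 `CC(Sc1nnc(-c2ccncc2)s1)C(=O)NCc1ccccc1` reaches only a limit of this assay, > 50000 nM, and no number behind it is known. The same point is summarised in the limit of > 50000 nM in this assay, at which 1 of the 3 values shown sits. No two of these compounds differ in a single place, so no measured step is available to guide an expectation, and what compounds 2 and 3 show about their own values cannot be tied to a structural change from compound 1.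

Compound 4 `O=C(CCSc1nnc(-c2ccncc2)s1)Nc1ccc(Cl)cc1Cl` is the one to be measured. It differs from compound 1 by chloro in place of hydrogen on an aromatic carbon; read one bond further out, this is 4-chlorophenyl to 2,4-dichlorophenyl. For the measured compounds named here, with no measured step at hand, the change from compound 1 to compound 4 is expected to be small, at most a modest loss of tolerance and quite possibly within the usual scatter of this assay. The expected step is a 1.5-fold lower number from compound 1 to compound 4 (0.16 log units; within the scatter). Compound 4 is estimated at 5000 nM, with a range from 2000 nM to 15000 nM.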

Compound 4, half-maximal cytotoxic concentration: > 50000 nM
Compound 4: a limit, no number; the forecaster's own chance of this, stated with the estimate: 10%; middle value at least 10-fold (1.00 log units) from the limit.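

In this assay the series now has its first measured step, and it reads an at least 6.8-fold higher number from compound 1 to compound 4 (0.83 log units; beyond the scatter) for chloro in place of hydrogen on an aromatic carbon, ortho to a large group and meta to a chloro group. At this position, going from 4-chlorophenyl to 2,4-dichlorophenyl therefore goes with more compound being tolerated, and the step lies beyond the scatter. Compound 4 gives > 50000 nM, which is a limit of the assay and not a number, so the step has a lower bound but no known size, and the top of the range remains unresolved for this compound as for one other in the set: the limit of > 50000 nM in this assay, at which 2 of the 4 values shown sit.

Chloro is the only group shown at this position, so it remains open whether the step belongs to chloro itself or to any group placed there; fluoro, methyl, methoxy or an amine at the same carbon would separate these readings. For the compounds shown here, also open is whether the same change would carry over to the other compounds in the set, as no pair among them shows a chloro added at this place with the rest of the structure unchanged.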